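The compounds below may be only part of what the source reports. "The series", "measured", "known", "first", "only" and "open" are said of these compounds alone.

Working notes on the series. In an assay on HEK293 cells for agonist activity at transient receptor potential cation channel subfamily M member 8 (Homo sapiens), read by fluorescence and calcium flux, with a stated time of 15 min (a lower number here means that less compound is needed, a higher number that more compound is needed for the effect), compound 1 `CCCc1ccc(OCC(=O)N(CC)Cc2cccs2)cc1` gives 1810 nM and compound 3 `CCN(Cc1cccs1)C(=O)COc1ccc(Cl)cc1` gives 39 nM, while compound 2 `Cc1ccc(OCC(=O)N(Cc2cccs2)C2COC2)cc1` gives 23000 nM, the highest of the three numbers; its gap to compound 1 is the smaller and its gap to compound 3 the larger, both beyond the scatter. Among the measured compounds shown here, the only measured single-point step, a 46-fold lower number from compound 1 to compound 3 (1.67 log units; beyond the scatter), changes a group on an aromatic carbon and does not touch the amide-type nitrogen. Compound 4 `Cc1ccc(OCC(=O)N(Cc2cccs2)c2cnccn2)cc1` differs from compound 2 by pyrazin-2-yl in place of oxetan-3-yl on an amide-type nitrogen. Compounds 1 and 2 differ at the amide-type nitrogen but also on the aromatic carbon, so their two values give no clean reading for this position. For the measured compounds named here, no measured step bears on the change, so only a tentative move toward a lower number is expected, with wide uncertainty. Compound 4 is expected near 8000 nM (range 1500 nM to 40000 nM), the expected step being a 2.9-fold lower number from compound 2 to compound 4 (0.46 log units; beyond the scatter).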

Compound 4, half-maximal effective concentration: 1240 nM
Estimate against measurement, compound 4: 6.5-fold (0.81 log units) above; measured number below the stated range.
By their numbers in this assay, from the lowest: compound 3; then compounds 4 and 1 (each within the scatter of the next); then compound 2.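

In this assay the amide-type nitrogen now has a clean reading: pyrazin-2-yl in place of oxetan-3-yl gives a 19-fold lower number from compound 2 to compound 4 (1.27 log units; beyond the scatter) with the rest of the structure unchanged. The group on this nitrogen can therefore shift the number by a large step on its own. Nothing available explains the size of this step.

Open, from the compounds shown here alone, is whether a plain phenyl on this nitrogen would match pyrazin-2-yl, which would separate the aromatic ring from its nitrogen atoms. Also open, going by these compounds, is whether the step carries over when chloro stands on the aromatic carbon, as in compound 3.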